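Nitro in place of methoxy on the aryl of compound 1

This account rests on a few compounds, and the source may have more. Where it says the series, first, only, none or still open, it means among the compounds named here.

Compound 1 `CCCS(=O)(=O)Nc1ccc(F)c(C(=O)c2n[nH]c3ncc(-c4cccc(OC)c4)cc23)c1F` is one of three analogues that share a core and differ only in the aromatic group attached to it. In an assay for binding affinity to dual specificity mitogen-activated protein kinase kinase 4 (Homo sapiens), read by KINOMEscan, tested at 100 nM (on this read-out higher numbers stand for a weaker effect at the one concentration tested and lower numbers for a stronger effect), compound 1 gives 6.3%. Compound 2 `CCCS(=O)(=O)Nc1ccc(F)c(C(=O)c2n[nH]c3ncc(-c4ccc(N(C)C)cc4)cc23)c1F` gives 2.5%, and compound 3 `CCCS(=O)(=O)Nc1ccc(F)c(C(=O)c2n[nH]c3ncc(-c4ccc(C)c(C)c4)cc23)c1F` gives 20%. Compound 1 thus sits close to compound 2 and well apart from compound 3: the step of a number 3.8 percentage points lower from compound 1 to compound 2 (within the scatter) lies within the scatter, whereas a number 13.7 percentage points higher from compound 1 to compound 3 (beyond the scatter) and a number 17.5 percentage points higher from compound 2 to compound 3 (beyond the scatter) are modest steps beyond it.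

Compound 4 `CCCS(=O)(=O)Nc1ccc(F)c(C(=O)c2n[nH]c3ncc(-c4cccc([N+](=O)[O-])c4)cc23)c1F` differs from compound 1 by one change: nitro in place of methoxy on an aromatic carbon. Among the compounds with values here, no measured step exchanges a methoxy for a nitro group, so the only guidance is how far the read-out moved across the three aromatic groups already measured: a change within the scatter from compound 1 to compound 2, and modest steps beyond it to compound 3. A step of at most modest size, or none beyond the scatter, is therefore expected in this assay. Compound 4 is estimated at 8%, with a range from 2% to 25%. The expected step is a number 1.7 percentage points higher from compound 1 to compound 4 (within the scatter).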

Compound 4, a percentage reported as activity, at one concentration (the size of the read-out at that concentration, not a potency): 15%
Beside the measured number, compound 4's estimate is 7 percentage points below it; the measured number falls inside the stated range.
By their numbers in this assay, from the lowest: compounds 2, 1, 4 and 3 (each within the scatter of the next, the first and the last beyond it).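

In this assay, the nitro for methoxy exchange, on an aromatic carbon meta to a large group, gives a step of a number 8.7 percentage points higher from compound 1 to compound 4 (within the scatter), so the earlier picture of this position gains a group that cannot be told apart from methoxy here. Within the data shown here, the same compound also stands close to the 3,4-dimethylphenyl analogue, with a step of a number 5 percentage points lower from compound 3 to compound 4 (within the scatter), and only the step of a number 12.5 percentage points higher from compound 2 to compound 4 (beyond the scatter) separates it from another compound, so compound 4 bridges compound 1 and compound 3, which lie apart from each other. Nothing available accounts for where the nitro compound falls.

The compounds shown leave open whether an amine or a carboxylic acid on this aromatic carbon would move the read-out further than nitro does. They also leave open what a longer chain such as ethoxy would do at this place.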